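The compounds below may be only part of what the source reports. "The series", "measured", "known", "first", "only" and "open" are said of these compounds alone.

Measured so far:
compound 1, `Cc1nc(C)c(-c2nn(-c3ccc(F)cc3)cc2/C=C/C(=O)c2cc(Cl)c(C)cc2O)s1`: > 250 ug/mL
compound 2, `Cc1nc(C)c(-c2nn(-c3ccc(F)cc3)cc2/C=C/C(=O)c2c(O)cc(C)c(Cl)c2C)s1`: 33.5 ug/mL
compound 3, `Cc1nc(C)c(-c2nn(-c3ccc(F)cc3)cc2C2CC(c3cc(Cl)c(C)cc3O)=NN2)s1`: 146 ug/mL

In an ADME assay on A549 cells (Homo sapiens) for inhibition, read by MTT assay (a higher number here means a weaker inhibitor of growth, a lower number a stronger inhibitor of growth), compound 1 gives only a limit, > 250 ug/mL, which is the limit of > 250 ug/mL in this assay, at which 1 of the 3 values shown sits. Compound 2 gives 33.5 ug/mL and compound 3 gives 146 ug/mL. The change from compound 1 to compound 2 is methyl in place of hydrogen on an aromatic carbon; it produced an at least 7.4-fold lower number from compound 1 to compound 2 (0.87 log units; beyond the scatter). The cores of compound 1 and compound 3 differ, but that difference is not broken down here. Compound 4, `Cc1nc(C)c(-c2nn(-c3ccc(F)cc3)cc2C2CC(c3c(O)cc(C)c(Cl)c3C)=NN2)s1`, is not yet measured; it stands to compound 3 as compound 2 stands to compound 1, the same change: methyl in place of hydrogen on an aromatic carbon. Because the same change gave an at least 7.4-fold lower number from compound 1 to compound 2 (0.87 log units; beyond the scatter), a lower number is expected for compound 4 in this assay. The expected step is a 4.9-fold lower number from compound 3 to compound 4 (0.69 log units; beyond the scatter). Compound 4 is estimated at 30 ug/mL, between 10 ug/mL and 90 ug/mL.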

Compound 4, concentration for 50% growth inhibition: 43.4 ug/mL
Beside the measured number, compound 4's estimate is 1.4-fold (0.16 log units) below it, within the range that was stated.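

In this assay, methyl in place of hydrogen on an aromatic carbon again lowers the number on the second core, giving a 3.4-fold lower number from compound 3 to compound 4 (0.53 log units; beyond the scatter). Set side by side, the two steps point the same way, but their sizes cannot be ranked: the same change on two cores in this assay, an at least 7.4-fold lower number (0.87 log units; beyond the scatter) from compound 1 to compound 2 and a 3.4-fold lower number (0.53 log units; beyond the scatter) from compound 3 to compound 4; the limit leaves it open whether they differ. The step on the core of compound 1 rests on a limit and not a number: the limit of > 250 ug/mL in this assay, at which 1 of the 4 values shown sits.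

Two cores show a shared direction for this one change, and they say nothing about any further core. The compounds shown leave open whether a larger group at the same place, such as ethyl, or an amine there would move the number in the same direction on both cores.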